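A few compounds are considered here, and "the series" means these few. Any claim that something is new, unique, unknown or untested is made for them only; others in the source may bear on it.

Compound 1 `CC1(C)CCOc2ccc(NC(=S)Nc3ccc(OC(F)(F)F)cc3)cc21` was tested in a functional assay on A2780 cells (Homo sapiens) for inhibition, with a stated time of 72 h (on this read-out higher numbers stand for weaker inhibition and lower numbers for stronger inhibition), where compound 1 gives 4300 nM. Compound 2 `CCC1(CC)CC(CC)(CC)c2cc(NC(=O)Nc3ccc(OC(F)(F)F)cc3)ccc2O1` is built on a different core, and how the two cores differ is not broken down here; in this assay compound 2 gives 3000 nM. Compound 3 `CCC1(CC)CC(CC)(CC)c2cc(NC(=O)Nc3ccc(C(F)(F)F)cc3)ccc2O1` carries trifluoromethyl in place of trifluoromethoxy on an aromatic carbon and gives 2000 nM in this assay, so that the step of a 1.5-fold lower number from compound 2 to compound 3 (0.18 log units; within the scatter) is a small one. Compound 4 `CC1(C)CCOc2ccc(NC(=S)Nc3ccc(C(F)(F)F)cc3)cc21` is still to be measured; it differs from compound 1 by trifluoromethyl in place of trifluoromethoxy on an aromatic carbon, the same change that turns compound 2 into compound 3. Because the step of a 1.5-fold lower number from compound 2 to compound 3 (0.18 log units; within the scatter) stayed small, a similarly small step a 1.5-fold lower number from compound 1 to compound 4 (0.17 log units; within the scatter) is expected here. In this assay compound 4 is therefore estimated at 2900 nM, between 1500 nM and 5500 nM.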

Compound 4, half-maximal inhibitory concentration: 5500 nM
Compound 4: middle estimate off by 1.9-fold (0.28 log units), on the low side, within the range that was stated.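

In this assay, trifluoromethyl in place of trifluoromethoxy gives a 1.3-fold higher number from compound 1 to compound 4 (0.11 log units; within the scatter), so the change stays small on the core of compound 1, as it did on the core of compound 2. Set side by side, the two steps do not differ: the same change on two cores in this assay, a 1.5-fold lower number (0.18 log units; within the scatter) from compound 2 to compound 3 and a 1.3-fold higher number (0.11 log units; within the scatter) from compound 1 to compound 4, 1.9-fold (0.28 log units) apart, within the scatter of two such steps. This shows that the change can be carried between these two cores without a step beyond the scatter, but with one pair per core it does not fix a direction for the change or show that it would stay small on any other core.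

The compounds shown leave open how a nitrile, a chlorine or a methoxy group would read on the same aromatic carbon. They also leave open whether an amine or a carboxylic acid would be tolerated there.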